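The source may hold more compounds than are shown below. What is called first, only, known or untested is meant among the compounds shown, and "the series" means these compounds.

Of the compounds shown here, two built on a shared core have been measured in an assay on HeLa cells for displacement of a labelled ligand from 5-hydroxytryptamine receptor 6 (Homo sapiens); on this read-out lower numbers stand for stronger inhibition and higher numbers for weaker inhibition. Compound 1, `CSc1nc2ccc(C(N)=O)cn2c(=N)c1S(=O)(=O)c1ccccc1`, gives 8.8 nM in this assay. Compound 2, `CSc1nc2c(C)cccn2c(=N)c1S(=O)(=O)c1ccccc1`, gives 3.4 nM in this assay. Of these two numbers, compound 2 holds the lower one, and compound 1 sits at a number that lies beyond the scatter above it. The two compounds differ from each other in more than one place, so their pair says only what their two values show and does not isolate any single change.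

Compound 3, `CSc1nc2c(Cc3ccccc3)cccn2c(=N)c1S(=O)(=O)c1ccccc1`, has not yet been measured in this assay. It differs from compound 2 in exactly one place: phenyl in place of hydrogen on a saturated chain carbon bound to an aromatic carbon. Going by the values given here, no measured pair in this set carries that change, so its effect in this assay is not known from the numbers at hand. In the absence of any anchor, a modest move toward a higher number is expected, and the expected step is a 2.1-fold higher number from compound 2 to compound 3 (0.31 log units; beyond the scatter). Compound 3 is therefore estimated to give 7 nM in this assay, with a range from 2 nM to 30 nM.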

Compound 3, half-maximal inhibitory concentration: 330 nM
Beside the measured number, compound 3's estimate is 47-fold (1.67 log units) below it; measured number outside the range, above it.
By their numbers in this assay, from the lowest: compound 2; then compound 1; then compound 3.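

In this assay, phenyl in place of hydrogen on a saturated chain carbon bound to an aromatic carbon, which reads as methyl to benzyl, brings a 97-fold higher number from compound 2 to compound 3 (1.99 log units; beyond the scatter) and so marks a large loss of inhibition on this read-out. Compound 1 and compound 2 differ in more than one place and could say nothing about any single change, whereas this pair isolates one and shows that, on the core of compound 2, benzyl at this place is far less well tolerated than methyl. The numbers show only the size of this step, and no supporting data explain why the added phenyl costs so much.

The compounds shown leave open whether the loss follows from the phenyl ring itself or would already appear with a short chain such as ethyl in place of the methyl, and whether an amine or a carboxylic acid on the same chain carbon would behave differently. They also leave open whether the same change would cost as much on the core of compound 1, which carries a carboxamide instead.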